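Methyl for Chloro on a Diaryl Urea Growth Inhibitor

A few compounds are considered here, and "the series" means these few. Any claim that something is new, unique, unknown or untested is made for them only; others in the source may bear on it.

Measured so far:
compound 1 `O=C(Nc1ccc(Oc2ccc(-c3nccs3)cc2)cc1)Nc1ccc(Cl)c([N+](=O)[O-])c1` gives 72.8% in a functional assay on MDA-MB-231 cells (Homo sapiens) for inhibition, read by MTT assay and WST assay, with a stated time of 72 h, tested at 10 uM; on this read-out lower numbers stand for less inhibition of growth and higher numbers for more inhibition of growth at the one concentration tested
compound 2 `O=C(Nc1ccc(Oc2ccc(-c3nccs3)cc2)cc1)Nc1cc(Br)cc(C(F)(F)F)c1` gives 72.8% in this assay
compound 3 `O=C(Nc1ccc(Cl)cc1)Nc1ccc(Oc2ccc(-c3ncc[nH]3)cc2)cc1` gives 47.6% in this assay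

Compound 3 stands lowest of the three numbers; compound 1 and compound 2 lie at one value, and the step of no change at the digits printed from compound 1 to compound 2 (within the scatter) shows that swapping groups on the outer aryl of the urea left the read-out unmoved. Compound 4 `Cc1ccc(NC(=O)Nc2ccc(Oc3ccc(-c4ncc[nH]4)cc3)cc2)cc1` differs from compound 3 by methyl in place of chloro on an aromatic carbon. Among the measured compounds shown here, no measured pair covers this exchange; the one measured step, no change at the digits printed from compound 1 to compound 2 (within the scatter), touches the same outer aryl but with other groups, so it bears only loosely. On that basis no step beyond the scatter is expected. Compound 4 is therefore estimated to give 45% in this assay, between 25% and 65%, a step of a number 2.6 percentage points lower from compound 3 to compound 4 (within the scatter).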

Compound 4, percent growth inhibition at one concentration: 49.3%
The estimate for compound 4 lay 4.3 percentage points below the measured number, and the stated range covers the measured number.
By their numbers in this assay, from the lowest: compounds 3 and 4 (each within the scatter of the next); then compounds 1 and 2 (each within the scatter of the next).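

In this assay the change from 4-chlorophenyl to 4-methylphenyl gives a number 1.7 percentage points higher from compound 3 to compound 4 (within the scatter). The earlier step involved other groups on a different core, whereas this pair tests chloro against methyl directly at this position, and the read-out at the one concentration tested does not separate them. Nothing measured here offers an explanation for this result. From the compounds shown here alone, whether an amine, a carboxylic acid or a methoxy group at the same position would also leave the read-out unmoved remains open, as does whether chloro and methyl would stay level on the core of compound 1.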